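Plasma Stability From Compound 2 to Compound 3

The source may report more compounds than this note shows. Statements on the series, on what has been measured and on what is new or still open speak of the compounds shown alone.

- compound 1 `COc1ccc(C(=O)O)cc1-c1cccc(COc2ccc3c(c2)CN(C2CCCC2)C3=O)c1`: 100%
- compound 2 `O=C(O)c1ccc(Cl)c(-c2cccc(COc3ccc4c(c3)CN(C3CCCC3)C4=O)c2)c1`: 100%

Among the measured compounds shown here, in an ADME assay on a cell-free system (plasma, Rattus norvegicus) for metabolic stability, read by LC-MS, with a stated time of 1 h, at 37 degrees C, tested at 100 uM (a lower number here means that less of the compound is left, a higher number that more of the compound is left), compound 2 gives 100%, level with compound 1, its only measured neighbour. The next structure is compound 3 `COc1ccc(-c2cccc(COc3ccc4c(c3)CN(C3CCCC3)C4=O)c2)cc1C(=O)O`, which keeps the shared core. The change is 3-carboxy-4-methoxyphenyl in place of 5-carboxy-2-chlorophenyl on an aromatic carbon. For the measured compounds named here, one measured step bears on this: no change at the digits printed from compound 1 to compound 2 (within the scatter), where chloro took the place of methoxy on an aromatic carbon. Going by the values given here, that is thin evidence, since it is a single step and no measured compound carries the 3-carboxy-4-methoxyphenyl group. No step beyond the scatter is therefore expected in this assay, and the estimated step is a number 2 percentage points lower from compound 2 to compound 3 (within the scatter). For compound 3 the expected value is 98%, with an estimated range of 88% to 102%.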

Compound 3, percent of the compound remaining: 100%
Compound 3: middle estimate off by 2 percentage points, on the low side; measured number inside the range.
By their numbers in this assay, from the lowest: compounds 1, 2 and 3 (each within the scatter of the next).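

In this assay, among the compounds shown here, there is no change at the digits printed from compound 2 to compound 3 (within the scatter) when 3-carboxy-4-methoxyphenyl takes the place of 5-carboxy-2-chlorophenyl, so this larger swap of the whole aromatic group on the shared core leaves the read-out as flat as the single chloro-for-methoxy step did. There is also no change at the digits printed from compound 1 to compound 3 (within the scatter) in this assay when 3-carboxy-4-methoxyphenyl takes the place of 5-carboxy-2-methoxyphenyl, a change in which the two groups differ only in the numbers in their names, and so this renumbering adds nothing measurable to the picture at this position. Nothing available explains why the read-out stays the same across these changes.

On these data alone, all three compounds carry a carboxy group on this aromatic ring, so it remains open how a methyl ester or an amine in its place would behave in this assay. Also open, as far as these compounds go, is whether a group without chlorine or methoxy, such as a longer alkyl chain, would leave the read-out where it stands.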